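Methoxy to Hydroxy: What Compound 4 May Show

The compounds below may be only part of what the source reports. "The series", "measured", "known", "first", "only" and "open" are said of these compounds alone.

In an ADME assay on L6 cells (Rattus norvegicus) for cytotoxicity (a lower number here means a stronger inhibitor, a higher number a weaker inhibitor), compound 1 `c1c[nH]c(-c2ccc(-c3cc4cc(-c5ncc[nH]5)ccc4o3)cc2)n1` gives 3300 nM, a measured number. Compound 2 `CC(C)NC(=N)c1cccc(-c2cc3ccc(C(=N)NC(C)C)cc3o2)c1` reads > 200000 nM, which is only a limit of the assay. From the compounds shown here alone, compound 3 `COc1ccc(C(=N)NC(C)C)cc1-c1cc2ccc(C(=N)NC(C)C)cc2o1` reads > 175000 nM, also only a limit, so its true position remains unknown. Compound 4 `CC(C)NC(=N)c1ccc(O)c(-c2cc3ccc(C(=N)NC(C)C)cc3o2)c1` has hydrogen in place of methyl on an oxygen on an aromatic ring, turning methoxy into hydroxy. Among the measured compounds shown here, the one measured step at this spot is a step that the two limits leave unreadable from compound 2 to compound 3, methoxy in place of hydrogen on an aromatic carbon. It offers no size to build on, so no step beyond the scatter is expected, and the estimated change is an at least 1.1-fold lower number from compound 3 to compound 4 (0.06 log units; that floor lies within the scatter). For compound 4, the estimate is 150000 nM, with an expected range of 40000 nM to 300000 nM.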

Compound 4, half-maximal inhibitory concentration: > 187000 nM
Compound 4: no number, only a limit; the forecaster's own chance of this, stated with the estimate: 65%; middle value at least 1.2-fold (0.09 log units) away from the limit.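

Among the compounds shown here, compound 2, compound 3 and compound 4 each give only a limit, not a number, so no step between them can be read. From the compounds shown here alone, whether methoxy or hydroxy shifts the true value in this assay stays open.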